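A few compounds are considered here, and "the series" means these few. Any claim that something is new, unique, unknown or untested is made for them only; others in the source may bear on it.

Measured compounds in an ADME assay on HFF cells (Homo sapiens) for cytotoxicity, with a stated time of 8 days; on this read-out lower numbers stand for higher toxicity in this test and higher numbers for lower toxicity in this test:
Compound 1, `CCOc1nc(N)nc2c1ncn2/C=C1/CC1(CO)CO`, gives > 300000 nM, a limit of the assay rather than a number.
Compound 2, `CCCCCCOc1nc(N)nc2c1ncn2/C=C1/CC1(CO)CO`, gives > 200000 nM, again a limit.
Compound 3, `CCCCOc1nc(N)nc2c1ncn2/C=C1/CC1(CO)CO`, gives > 300000 nM, also a limit.

Compound 3 thus stands at a limit, and the two further values shown are limits as well. Compound 4 is `CC(C)Sc1nc(N)nc2c1ncn2/C=C1/CC1(CO)CO`. Its change from compound 3 is: isopropylsulfanyl in place of butoxy on an aromatic carbon. The measured steps all alter the saturated chain carried by an oxygen on an aromatic ring: a step that the two limits leave unreadable from compound 1 to compound 2, a step that the two limits leave unreadable from compound 1 to compound 3 and a step that the two limits leave unreadable from compound 2 to compound 3. None of them can be read as a size, so they offer no number to carry over. Since every value shown is a limit, the step of a number no higher from compound 3 to compound 4 (the limit leaves the size open) is expected to be none beyond the scatter. Compound 4 is estimated at 300000 nM, within 100000 nM to 1000000 nM.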

Compound 4, half-maximal cytotoxic concentration: > 300000 nM
Compound 4: only a limit was reported; the forecaster's own chance of this, stated with the estimate: 80%; the middle value lies on the limit itself.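

Among the compounds shown here, no step from compound 1, compound 2 or compound 3 to compound 4 can be read as a size, since all four results are limits rather than numbers. The compounds shown leave open what true value any of them has in this assay, and whether changing the group on the shared core alters it.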